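Working notes on a cytotoxicity series

The source may report more compounds than this note shows. Statements on the series, on what has been measured and on what is new or still open speak of the compounds shown alone.

Compound 1 `Cc1ccc(Nc2nc(C)c(C(=O)/C=C/c3ccc(Cl)cc3)s2)cc1` was tested in a functional assay on BGC-823 cells (Homo sapiens) for cytotoxicity, read by MTT assay; a lower number here means a stronger inhibitor, a higher number a weaker inhibitor. In this assay compound 1 gives > 25000 nM, which is a limit of the assay and not a number. Compound 2 `Cc1ccc(Nc2nc(C)c(C(=O)/C=C/c3ccccc3Cl)s2)cc1` gives > 25000 nM in this assay, again only a limit. The step that the two limits leave unreadable from compound 1 to compound 2 cannot be read because both values sit at the limit of > 25000 nM in this assay, at which 2 of the 2 values shown sit. Compound 3 `Cc1nc(Nc2ccc(Cl)cc2)sc1C(=O)/C=C/c1ccc(Cl)cc1` differs from compound 1 by chloro in place of methyl on an aromatic carbon, that is 4-methylphenyl to 4-chlorophenyl, (4-methylphenyl)amino to (4-chlorophenyl)amino. Among the compounds with values here, no measured step bears on this change, and compound 1 stands only at a limit, so no shift beyond the scatter is expected in either direction. Compound 3 is expected at 35000 nM, with a range from 10000 nM to 120000 nM, most likely reported again as a limit. This corresponds to an expected step that the limit leaves unreadable from compound 1 to compound 3.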

Compound 3, half-maximal inhibitory concentration: > 25000 nM
Compound 3: only a limit was reported; the forecaster's own chance of this, stated with the estimate: 80%; the middle value does not contradict the limit.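

No step can be read from compound 1 to compound 3, as both stand only at a limit of the assay: the limit of > 25000 nM in this assay, at which 3 of the 3 values shown sit.
The compounds shown leave open whether chloro in place of methyl changes cytotoxicity at all.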